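The compounds below may be only part of what the source reports. "The series", "measured", "known", "first", "only" and "open" are said of these compounds alone.

Measured in a functional assay on MCF7 cells (Homo sapiens) for cytotoxicity, read by CellTiter-Glo, with a stated time of 5 days; a lower number here means a stronger inhibitor, a higher number a weaker inhibitor:
compound 1 `CC/C(=C(/c1ccc(/C=C/C(=O)O)cc1)c1ccc2[nH]c(=O)sc2c1)c1ccccc1`, 158 nM
compound 2 `CC/C(=C(/c1ccc(/C=C/C(=O)O)nc1)c1ccc2[nH]ncc2c1)c1ccccc1`, 210 nM
compound 3 `CC/C(=C(/c1ccc(/C=C/C(=O)O)cc1)c1ccc2[nH]ncc2c1)c1cccc(Cl)c1`, 12 nM

Compound 3 gives the lowest number of the three; compound 1 is the nearest and compound 2 the furthest, and both gaps lie beyond the scatter. Compound 4 `CC/C(=C(/c1ccc(/C=C/C(=O)O)cc1)c1ccc2[nH]ncc2c1)c1ccncc1Cl` has not yet been measured. Against compound 3 the change is 3-chloropyridin-4-yl in place of 3-chlorophenyl on a double-bonded chain carbon bound to a double-bonded chain carbon and a saturated chain carbon. Going by the values given here, no pair of measured compounds shows this change, so its effect here is unknown. In this assay a modest rise in the number is expected for compound 4, of a size near the edge of the scatter, with the step of a 2.5-fold higher number from compound 3 to compound 4 (0.40 log units; beyond the scatter). Compound 4 is estimated at 30 nM, with a range from 8 nM to 120 nM.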

Compound 4, half-maximal inhibitory concentration: 4 nM
Compound 4: middle estimate off by 7.5-fold (0.88 log units), on the high side, and the stated range ends above it.
By their numbers in this assay, from the lowest: compound 4; then compound 3; then compounds 1 and 2 (each within the scatter of the next).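

In this assay, going by these compounds alone, this position takes a ring nitrogen: 3-chloropyridin-4-yl in place of 3-chlorophenyl gives a 3.0-fold lower number from compound 3 to compound 4 (0.48 log units; beyond the scatter) in the only single-place step. The number falls even with a hydrogen-bond acceptor added to the group at this position. Nothing on hand gives a reason for the drop. Still open, going by these compounds, is how an unsubstituted pyridin-4-yl or a 3-fluoropyridin-4-yl would read at this position. Also open, on these data alone, is whether the same change would lower the number on the core of compound 1.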